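The source may report more compounds than this note shows. Statements on the series, on what has been measured and on what is new or still open speak of the compounds shown alone.

Within the data shown here, in an ADME assay on a cell-free system (plasma, Rattus norvegicus, strain Wistar) for metabolic stability, read by HPLC, tested at 1 uM (a lower number here means that the compound disappears faster, a higher number that the compound lasts longer), compound 1 `NC(=O)c1cccc(-c2cccc(OC(=O)NCCCCc3ccccc3)c2)c1` gives 0.07 h, the lower of the two numbers available so far. Compound 2 `O=C(NC1CCCCC1)Oc1cccc(-c2ccccc2)c1` gives 0.712 h, a gap well beyond the usual scatter. Compound 3 `O=C(NCCCCc1ccccc1)Oc1cccc(-c2ccccc2)c1` keeps the chain of compound 1 and alters one place: hydrogen in place of carbamoyl on an aromatic carbon. In words, it has hydrogen in place of carbamoyl on an aromatic carbon, meta to a large group. Among the measured compounds shown here, no measured pair shows this change on its own, so any forecast is loose. Compound 1 differs from compound 2 in the chain as well as in the carbamoyl group, so the 0.712 h of compound 2 offers only a weak hint of a longer half-life. A moderate rise is expected, a 2.9-fold higher number from compound 1 to compound 3 (0.46 log units; beyond the scatter). For compound 3 the estimated half-life is 0.2 h, with a range of 0.06 h to 0.7 h.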

Compound 3, half-life in the plasma assay: 0.11 h
Beside the measured number, compound 3's estimate is 1.8-fold (0.26 log units) above it, and the stated range covers the measured number.
By their numbers in the plasma assay, from the lowest: compounds 1 and 3 (each within the scatter of the next); then compound 2.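

Among these compounds, compound 1 and compound 3 differ only in the carbamoyl group, so this change can now be read on its own for the first time: in the plasma assay compound 1 gives 0.07 h and compound 3 gives 0.11 h. In the plasma assay, hydrogen in place of carbamoyl on this aromatic carbon, meta to a large group, gives a 1.6-fold higher number from compound 1 to compound 3 (0.20 log units; within the scatter), so the half-life does not separate the pair. In a physicochemical assay, read by HPLC, in phosphate buffer, at pH 7.0 (on this read-out higher numbers stand for a more stable compound and lower numbers for a less stable compound), compound 1 gives 18.8% and compound 3 gives 35.9%. In the physicochemical assay, the same change gives a number 17.1 percentage points higher from compound 1 to compound 3 (beyond the scatter), so the pair separates only in the physicochemical assay.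

From the compounds shown here alone, whether a nitrile, a carboxylic acid or an amine at this place would read like carbamoyl or like hydrogen stays open. Also open, going by these compounds, is whether a shorter chain would move the half-life in the plasma assay towards the value of compound 2, 0.712 h.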